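The source may report more compounds than this note shows. Statements on the series, on what has been measured and on what is new or still open speak of the compounds shown alone.

Within the data shown here, in a functional assay on cells (Tumor Cell line, Homo sapiens) for cytotoxicity (a higher number here means a weaker inhibitor, a lower number a stronger inhibitor), compound 3 `CN(C)Cc1cc(C(=O)/C=C/c2ccc(Cl)c(Cl)c2)cc(CN(C)C)c1O` gives 2350 nM, the lowest of three numbers so far, against compound 2 `CN(C)Cc1cc(C(=O)/C=C/c2c(Cl)cccc2Cl)cc(CN(C)C)c1O` at 5880 nM and compound 1 `CN(C)Cc1cc(C(=O)/C=C/c2ccc(Cl)cc2)cc(CN(C)C)c1O` at 10000 nM. Compound 4 `Cc1ccc(/C=C/C(=O)c2cc(CN(C)C)c(O)c(CN(C)C)c2)cc1` keeps the shared core and differs at one group: 4-methylphenyl in place of 3,4-dichlorophenyl on a double-bonded chain carbon bound to a double-bonded chain carbon. The most relevant measured change is a 4.3-fold lower number from compound 1 to compound 3 (0.63 log units; beyond the scatter), modest and beyond the scatter, with chloro in place of hydrogen on an aromatic carbon. By contrast, a 1.7-fold lower number from compound 1 to compound 2 (0.23 log units; within the scatter) stays within the scatter. Among the measured compounds shown here, no measured compound carries 4-methylphenyl, so the comparison with the 4-chlorophenyl of compound 1 is only approximate. A modest rise is expected, roughly reversing that gain, and the expected change is a 3.0-fold higher number from compound 3 to compound 4 (0.47 log units; beyond the scatter). Compound 4 is estimated at 7000 nM, within a range of 2800 nM to 18000 nM.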

Compound 4, half-maximal inhibitory concentration: 17800 nM
The estimate for compound 4 lay 2.5-fold (0.41 log units) below the measured number; the measured number falls inside the stated range.
By their numbers in this assay, from the lowest: compound 3; then compounds 2, 1 and 4 (each within the scatter of the next, the first and the last beyond it).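

In this assay the 4-methylphenyl group at this double-bonded chain carbon gives a 7.6-fold higher number from compound 3 to compound 4 (0.88 log units; beyond the scatter) and also a 3.0-fold higher number from compound 2 to compound 4 (0.48 log units; beyond the scatter), so both dichlorophenyl groups give lower numbers than 4-methylphenyl. Methyl in place of chloro on the aromatic carbon gives only a 1.8-fold higher number from compound 1 to compound 4 (0.25 log units; within the scatter), so this change does not separate the two singly substituted rings. No measurement available here accounts for these differences. Still open, on these data alone, is whether methoxy or trifluoromethyl on this ring would give a number lower than that of compound 3. As far as these compounds go, a pyridyl ring in place of the phenyl is equally open.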